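This account rests on a few compounds, and the source may have more. Where it says the series, first, only, none or still open, it means among the compounds named here.

Compound 1 `CCN1CCN(c2cc(Nc3cc(C)nn3C(=O)C(C)(C)C)nc(N[C@H]3CCN(C(=O)c4ccc(Cl)cc4F)C3)n2)CC1`: 7.8%
Compound 2 `CCN1CCN(c2cc(Nc3cc(C)nn3C(=O)OC(C)(C)C)nc(N[C@H]3CCN(C(=O)c4ccc(Cl)cc4F)C3)n2)CC1`: 28.9%

In an ADME assay on the whole organism (Mus musculus, strain ICR) for pharmacokinetics, read by LC-MS, with a stated time of 24 h, at a dose of 10 mg/kg by the oral route (on this read-out higher numbers stand for higher oral bioavailability and lower numbers for lower oral bioavailability), compound 1 gives 7.8%, while compound 2 gives 28.9%. Compound 2 thus stands highest of the two numbers, with compound 1 nearest; the step of a number 21.1 percentage points higher from compound 1 to compound 2 (beyond the scatter) lies beyond the scatter.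

Compound 3 `CCOC(=O)n1nc(C)cc1Nc1cc(N2CCN(CC)CC2)nc(N[C@H]2CCN(C(=O)c3ccc(Cl)cc3F)C2)n1` differs from compound 2 by ethyl in place of tert-butyl on an oxygen next to a carbonyl group. Going by the values given here, no measured step bears directly on this change: the only step available, a number 21.1 percentage points higher from compound 1 to compound 2 (beyond the scatter), replaced tert-butyl by tert-butoxy on a carbonyl carbon, and both compound 2 and compound 3 keep the tert-butoxy-type oxygen link to the carbonyl. With nothing in hand that tells how shortening the chain on that oxygen moves this read-out, the expected step is a number 3.9 percentage points lower from compound 2 to compound 3 (within the scatter), within the scatter. Compound 3 is accordingly estimated at 25%, with a range from 8% to 45%.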

Compound 3, oral bioavailability: 54.5%
Estimate against measurement, compound 3: 29.5 percentage points below; measured number outside the range, above it.
By their numbers in this assay, from the lowest: compound 1; then compound 2; then compound 3.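

Read in this assay, the result shows that the group on an oxygen next to a carbonyl group matters in its own right: ethyl in place of tert-butyl gives a number 25.6 percentage points higher from compound 2 to compound 3 (beyond the scatter) at this position, so the oxygen link alone does not set the number. Ethoxy in place of tert-butyl on a carbonyl carbon gives a number 46.7 percentage points higher from compound 1 to compound 3 (beyond the scatter) and is the only step among these compounds printed as large. Nothing measured here accounts for either step. The compounds shown leave open how methyl, isopropyl or a longer chain such as n-butyl on that oxygen would read, and two groups there define no trend with chain size. They also leave open how a dimethylamino group on the carbonyl carbon would compare with ethoxy.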